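The compounds below may be only part of what the source reports. "The series", "measured", "known", "first", "only" and "open" are said of these compounds alone.

Three compounds share one core and differ only in the group on the aromatic ring that carries the hydrazine. Compound 1 `CC(=O)Nc1ccc(S(=O)(=O)NNc2ccc(C#N)cc2)cc1` bears a cyano group, and in an assay for inhibition of Indoleamine 2,3-dioxygenase 1 (Homo sapiens), read by spectrophotometry, with stated times of 1 h and 4 h (a lower number here means a stronger inhibitor, a higher number a weaker inhibitor), compound 1 gives 5670 nM. Compound 2 `CC(=O)Nc1ccc(S(=O)(=O)NNc2ccc(S(N)(=O)=O)cc2)cc1` bears a sulfamoyl group, and in this assay compound 2 gives 2480 nM. Compound 3 `CC(=O)Nc1ccc(S(=O)(=O)NNc2ccc(C(F)(F)F)cc2)cc1` bears a trifluoromethyl group, and in this assay compound 3 gives 1610 nM. Compound 3 has the lowest number of the three, but its standing is mixed: a 3.5-fold lower number from compound 1 to compound 3 (0.55 log units; beyond the scatter), whereas a 1.5-fold lower number from compound 2 to compound 3 (0.19 log units; within the scatter), so compound 3 and compound 2 cannot be told apart, while a 2.3-fold lower number from compound 1 to compound 2 (0.36 log units; beyond the scatter).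

Compound 4 `CC(=O)Nc1ccc(S(=O)(=O)NNc2ccc(Cl)cc2)cc1` has not yet been measured. Its change from compound 3 is chloro in place of trifluoromethyl on an aromatic carbon. Among the measured compounds shown here, none of the three measured steps exchanges a group for chloro, so no step bears on it directly. What the steps do show is that changing the group at this position moves the number in this assay only modestly, and the step closest in kind, a 1.5-fold lower number from compound 2 to compound 3 (0.19 log units; within the scatter), stayed within the scatter. The step from compound 3 to compound 4 is therefore expected to be small, a 1.5-fold higher number from compound 3 to compound 4 (0.17 log units; within the scatter). Compound 4 is estimated at 2400 nM, with a range from 1000 nM to 6000 nM.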

Compound 4, half-maximal inhibitory concentration: 155 nM
Compound 4: the middle estimate sits 15-fold (1.19 log units) above what was measured, outside the stated range (below it).
By their numbers in this assay, from the lowest: compound 4; then compounds 3 and 2 (each within the scatter of the next); then compound 1.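

The three earlier compounds made this position, para to a large group, look as if exchanging one group for another changed little, but chloro shows that it can matter a great deal in this assay: replacing trifluoromethyl, with 4 heavy atoms, by chloro, with 1 heavy atom, gives a 10-fold lower number from compound 3 to compound 4 (1.02 log units; beyond the scatter). The other two exchanges point the same way, with a 16-fold lower number from compound 2 to compound 4 (1.20 log units; beyond the scatter) and a 37-fold lower number from compound 1 to compound 4 (1.56 log units; beyond the scatter), so the group at this place can move the number far more than the differences among cyano, sulfamoyl and trifluoromethyl suggested. Trifluoromethyl and chloro have the same counts of hydrogen-bond donors and acceptors and no net charge, so those counts do not separate the two groups.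

Nothing given here explains why chloro stands so far from the other three groups. On these data alone, it also remains open whether this low number is particular to chloro or would be shared by other small groups at the same place, such as fluoro, bromo, methyl or methoxy.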